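Indanone series: methoxy on the pendant phenyl ring

The source may report more compounds than this note shows. Statements on the series, on what has been measured and on what is new or still open speak of the compounds shown alone.

Measured so far:
compound 1, `COc1cc2c(cc1OC)C(c1cc(OC)c(OC)c(OC)c1)CC2=O` — 140000 nM
compound 2, `COc1cc(OC)c(C2CC(=O)c3cc(OC)c(OC)c(OC)c32)c(OC)c1` — 226000 nM
compound 3, `COc1cc2c(c(OC)c1OC)C(c1ccccc1)CC2=O` — >= 250000 nM

Compound 1, compound 2 and compound 3 share the indanone core and differ in the substitution of the pendant aromatic ring. In a functional assay on Caco-2 cells (Homo sapiens) for cytotoxicity, read by MTT assay, with a stated time of 24 h (a higher number here means a weaker inhibitor, a lower number a stronger inhibitor), compound 1 gives 140000 nM and compound 2 gives 226000 nM. Compound 3 carries an unsubstituted pendant ring, and in this assay compound 3 is reported only as a limit, >= 250000 nM; this is the limit of >= 250000 nM in this assay, at which 1 of the 3 values shown sits, so compound 3 cannot be placed on the numbers at all.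

Compound 4, `COc1cccc(C2CC(=O)c3cc(OC)c(OC)c(OC)c32)c1`, is the next step. The change from compound 3 to compound 4 is methoxy in place of hydrogen on an aromatic carbon — methoxy in place of hydrogen on an aromatic carbon, meta to a large group; read one bond further out, phenyl to 3-methoxyphenyl. Among the measured compounds shown here, no step between measured compounds is available for it. The methoxy-bearing compound 1 and compound 2 have numbers where compound 3 has only a limit, which suggests at most a modest move toward stronger inhibition in this assay, possibly none beyond the scatter.

Compound 4 is expected at about 220000 nM, in the range 110000 nM to 450000 nM. The expected step is an at least 1.1-fold lower number from compound 3 to compound 4 (0.05 log units; that floor lies within the scatter), with a real chance that only a limit is again reported.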

Compound 4, half-maximal inhibitory concentration: >= 250000 nM
Compound 4: only a limit was reported (the forecaster's own chance of this, stated with the estimate: 50%); middle value at least 1.1-fold (0.05 log units) away from the limit.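

Compound 3 and compound 4 are both reported only as limits in this assay, so no step can be read between them: the limit of >= 250000 nM in this assay, at which 2 of the 4 values shown sit.

Going by these compounds, whether methoxy in place of hydrogen on an aromatic carbon changes the read-out in this assay at all remains open.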